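The source may report more compounds than this note shows. Statements on the series, on what has been measured and on what is new or still open speak of the compounds shown alone.

Of the compounds shown here, three sharing one core have been tested in a functional assay on J774 cells (Mus musculus) for cytotoxicity; a lower number here means a stronger inhibitor, a higher number a weaker inhibitor. Compound 1 `CCCN(CCC)c1c([N+](=O)[O-])cc(S(=O)(=O)Nc2ccc(C)cc2)cc1[N+](=O)[O-]` gives 11000 nM, compound 2 `CCCN(CCC)c1c([N+](=O)[O-])cc(S(=O)(=O)Nc2ccc(Cl)cc2)cc1[N+](=O)[O-]` gives 10000 nM, and compound 3 `CCCN(CCC)c1c([N+](=O)[O-])cc(S(=O)(=O)Nc2ccc(Cl)c(Cl)c2)cc1[N+](=O)[O-]` gives 7200 nM. The three numbers sit so close together that the data place compound 3 level with the other two. Swapping groups on the aromatic ring has so far moved little: the measured steps are a 1.1-fold lower number from compound 1 to compound 2 (0.04 log units; within the scatter), a 1.4-fold lower number from compound 2 to compound 3 (0.14 log units; within the scatter) and a 1.5-fold lower number from compound 1 to compound 3 (0.18 log units; within the scatter).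

Compound 4 `CCCN(CCC)c1c([N+](=O)[O-])cc(S(=O)(=O)N(C)c2ccccc2)cc1[N+](=O)[O-]`, not yet measured, has methyl(phenyl)amino in place of (3,4-dichlorophenyl)amino on a sulfonyl sulfur. The small steps above bear on the loss of the chloro groups and suggest that this part of the change will matter little. Among the compounds with values here, no tested compound carries a methyl on the sulfonamide nitrogen, so that part is untested and widens the uncertainty. No shift beyond the scatter is expected, and the estimated step is a 1.5-fold higher number from compound 3 to compound 4 (0.18 log units; within the scatter). For compound 4 the expected value is 11000 nM, with an estimated range of 5500 nM to 22000 nM.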

Compound 4, half-maximal inhibitory concentration: 11000 nM
Compound 4: the middle estimate sits on the measured number at the digits printed, and the stated range covers the measured number.
By their numbers in this assay, from the lowest: compounds 3, 2, 1 and 4 (each within the scatter of the next).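

Within the data shown here, compound 4 is the first compound here with a methyl on the sulfonamide nitrogen in place of the hydrogen, and in this assay all three comparisons stay within the scatter: a 1.5-fold higher number from compound 3 to compound 4 (0.18 log units; within the scatter), a 1.1-fold higher number from compound 2 to compound 4 (0.04 log units; within the scatter) and no change at the digits printed from compound 1 to compound 4 (within the scatter). So, among these four compounds, neither that hydrogen nor a methyl or chloro on the phenyl ring is needed to keep the number at this level, although compound 4 changes the nitrogen and the ring together, so the two changes cannot be separated. Nothing available explains this flat result.

As far as these compounds go, it remains open whether a longer chain on the sulfonamide nitrogen, such as propyl or benzyl, would shift the number. The same question stands for an amine or a carboxylic acid on the phenyl ring.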